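The source may hold more compounds than are shown below. What is called first, only, known or untested is meant among the compounds shown, and "the series" means these compounds.

Compound 1 `CCc1nn2c(C)cc(C)nc2c1Cc1ccc(/C=C/CN2CCNC(=O)C2)cc1`: 27 nM
Compound 2 `CCc1nn2c(C)cc(C)nc2c1Cc1ccc(/C=C/CN2CCNCC2=O)cc1`: 73 nM
Compound 3 `CCc1nn2c(C)cc(C)nc2c1Cc1ccc(CCCC2(O)CCN(C(C)C)CC2)cc1`: 63 nM

In a functional assay on HeLa cells for antagonist activity at G-prodeshotein coupled receptor 4 (Homo sapiens), read by HTRF and cAMP accumulation, with a stated time of 15 min (on this read-out lower numbers stand for stronger inhibition and higher numbers for weaker inhibition), compound 3 gives the second highest of the three numbers; compound 2 sits within the scatter of it, while compound 1 gives a lower number, beyond the scatter. Compound 4 `CCc1nn2c(C)cc(C)nc2c1Cc1ccc(CCCC2(O)CCNCC2)cc1` differs from compound 3 by hydrogen in place of isopropyl on an amine nitrogen in a ring. Going by the values given here, the only measured step, a 2.7-fold higher number from compound 1 to compound 2 (0.43 log units; beyond the scatter), concerns the oxopiperazine and not the amine nitrogen in a ring, so no step bears directly on this change. Compound 4 is therefore expected to stay close to compound 3, with a step of a 1.5-fold higher number from compound 3 to compound 4 (0.18 log units; within the scatter), a slight weakening that may not exceed the scatter. For compound 4 the estimate in this assay is 95 nM, ranging from 35 nM to 260 nM.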

Compound 4, half-maximal inhibitory concentration: 50 nM
Beside the measured number, compound 4's estimate is 1.9-fold (0.28 log units) above it; the measured number falls inside the stated range.
By their numbers in this assay, from the lowest: compounds 1, 4, 3 and 2 (each within the scatter of the next, the first and the last beyond it).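

In this assay hydrogen in place of isopropyl on the amine nitrogen in the ring gives numbers within the scatter of each other (a 1.3-fold lower number from compound 3 to compound 4 (0.10 log units; within the scatter)), so the isopropyl group is not needed for activity of this size. The 3-(4-hydroxypiperidin-4-yl)propyl chain of compound 4 also stays within the scatter of both oxopiperazine chains (a 1.5-fold lower number from compound 2 to compound 4 (0.16 log units; within the scatter); a 1.9-fold higher number from compound 1 to compound 4 (0.27 log units; within the scatter)). Nothing available explains these results. Going by these compounds, whether an acetyl or benzyl group on this nitrogen would be tolerated remains open, as does the contribution of the hydroxy group.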